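The source may hold more compounds than are shown below. What is called first, only, known or untested is meant among the compounds shown, and "the series" means these compounds.

In a functional assay on Bel-7402 cells (Homo sapiens) for inhibition, read by MTT assay, with a stated time of 24 h, tested at 0.1 ug/mL (on this read-out higher numbers stand for more inhibition of growth at the one concentration tested and lower numbers for less inhibition of growth), compound 1 (`CC(=O)SCCC(CCCCC(=O)O)SC(C)=O`) gives 10.3%. Two related compounds have also been measured: compound 2 (`O=C(CCCCC(S)CCS)Nc1ccccc1`) gives 0.85% and compound 3 (`O=C(CCCCC(S)CCS)Nc1cccc(C(F)(F)F)c1`) gives 2.85%. Compound 1 stands within the usual scatter of both, so these numbers set no order among the three.

The next compound is compound 4 (`CC(=O)SCCC(CCCCC(=O)Nc1ccccc1Cl)SC(C)=O`), which keeps the acetylated sulfur groups of compound 1 and changes the acid end: (2-chlorophenyl)amino in place of hydroxy on a carbonyl carbon. In words, (2-chlorophenyl)amino takes the place of hydroxy on a carbonyl carbon. Among the measured compounds shown here, no measured pair shows this exact replacement. Compound 2 and compound 3 do carry an aromatic amide at that carbonyl, but their sulfur atoms bear hydrogen rather than acetyl, so they offer only indirect guidance. For the measured compounds named here, the one measured step, a number 2 percentage points higher from compound 2 to compound 3 (within the scatter), is a change on the aromatic ring and stays within the scatter. Going by the values given here, nothing measured so far therefore points to a large effect in either direction, and no step beyond the scatter is expected in this assay.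

The expected change is a number 3.3 percentage points lower from compound 1 to compound 4 (within the scatter), which would remain within the scatter. The estimate for compound 4 is 7%, with an expected range from 0% to 20%.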

Compound 4, percent growth inhibition at one concentration: 6.61%
Estimate against measurement, compound 4: 0.4 percentage points above; the measured number falls inside the stated range.
By their numbers in this assay, from the lowest: compounds 2, 3, 4 and 1 (each within the scatter of the next).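

Among the compounds shown here, this is the first direct test of the acid end of the core with the acetylated sulfur groups kept in place: in this assay, there is a number 3.7 percentage points lower from compound 1 to compound 4 (within the scatter). The change puts 8 heavy atoms, including a six-membered aromatic ring, in place of the 1 oxygen of hydroxy on the carbonyl carbon, yet the result cannot be told apart from repeat-to-repeat variation. At this single concentration, then, the read-out shows no detectable effect of this replacement, and no measured property is available to bear on the result.

On these data alone, what stays open is whether any group on this carbonyl carbon can move the number beyond the scatter, and a simple methylamino group or a bulkier benzylamino group could help to define that range. A plain phenylamino group on the core of compound 4 would differ from it in one place only, so it could isolate the contribution of the chlorine, while a free thiol version of compound 4 could do the same for the acetyl groups.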